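Capping the Phenol: Expected Effect on Cytotoxicity

The source may hold more compounds than are shown below. What is called first, only, known or untested is meant among the compounds shown, and "the series" means these compounds.

Measured compounds:
Compound 1 `C=C1C(=O)[C@]23C[C@@]1(O)CC[C@H]2c1ccc(OS(=O)(=O)c2ccc(C)cc2)c(C)c1[C@@H]3Cn1cc(-c2ccccn2)nn1` gives 2310 nM in a functional assay on A549 cells (Homo sapiens) for cytotoxicity, read by MTT assay, with a stated time of 4 days; on this read-out higher numbers stand for weaker inhibition and lower numbers for stronger inhibition.
Compound 2 `C=C1C(=O)[C@]23C[C@@]1(O)CC[C@H]2c1ccc(OS(=O)(=O)c2ccc(C)cc2)c(C)c1[C@@H]3Cn1cc(-c2ccc(C)cc2)nn1` gives 1830 nM in this assay.
Compound 3 `C=C1C(=O)[C@]23C[C@@]1(O)CC[C@H]2c1ccc(O)c(C)c1[C@@H]3Cn1cc(-c2ccc(OC)cc2)nn1` gives 1250 nM in this assay.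

Compound 3 has the smallest of the three numbers in this assay, yet its gaps to compound 2 and to compound 1 both lie within the scatter, so the three compounds cannot be told apart on these data.

Compound 4 `C=C1C(=O)[C@]23C[C@@]1(O)CC[C@H]2c1ccc(OS(=O)(=O)c2ccc(C)cc2)c(C)c1[C@@H]3Cn1cc(-c2ccc(OC)cc2)nn1` is not yet measured. It differs from compound 3 by (4-methylphenyl)sulfonyl in place of hydrogen on an oxygen on an aromatic ring, so the free phenol of compound 3 is capped with the same group that compounds 1 and 2 already carry.

Within the data shown here, no measured pair differs in exactly this way. Among the measured compounds shown here, the only measured step, a 1.3-fold lower number from compound 1 to compound 2 (0.10 log units; within the scatter), concerns the aryl group on the triazole and stays within the scatter. Compounds 2 and 3 differ in two places at once, including this capping, and their values also lie within the scatter of each other. Nothing here points to a change beyond the scatter.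

Compound 4 is therefore expected to give about 1800 nM in this assay, between 900 nM and 3600 nM, meaning an expected step of a 1.4-fold higher number from compound 3 to compound 4 (0.16 log units; within the scatter).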

Compound 4, half-maximal inhibitory concentration: 1470 nM
Compound 4: middle estimate off by 1.2-fold (0.09 log units), on the high side; measured number inside the range.
By their numbers in this assay, from the lowest: compounds 3, 4, 2 and 1 (each within the scatter of the next).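

Among these compounds, this pair gives the first direct reading of the oxygen on the aromatic ring in this assay: with hydroxy replaced by ((4-methylphenyl)sulfonyl)oxy, the step of a 1.2-fold higher number from compound 3 to compound 4 (0.07 log units; within the scatter) shows that this cap, with its 10 heavy atoms, can replace the hydrogen without a change that stands out from the scatter. With the cap held the same, changing the aryl group on the triazole also separates nothing, as seen in the step of a 1.2-fold lower number from compound 2 to compound 4 (0.10 log units; within the scatter) for methoxy in place of methyl and the step of a 1.6-fold lower number from compound 1 to compound 4 (0.20 log units; within the scatter) for 4-methoxyphenyl in place of pyridin-2-yl. Nothing measured here bears on why these numbers stay so close.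

Still open, as far as these compounds go, is whether a different cap on this oxygen, such as a small methyl ether or an acetyl ester, would give a number beyond the scatter. The compounds shown also leave open what an amine or a carboxylic acid on the aryl group of the triazole would do in this cell assay.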